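Widening the Amine Ring of Compound 2

The source may report more compounds than this note shows. Statements on the series, on what has been measured and on what is new or still open speak of the compounds shown alone.

Compound 1 `CN(c1ncnc2c1ncn2Cc1ccccc1F)C1CC1` gives 6.8 mg/kg in a functional assay on the whole organism with Rattus norvegicus as the target, in the maximal electroshock model; a higher number here means that more compound is needed for the effect, a lower number that less compound is needed. Compound 2 `Fc1ccccc1Cn1cnc2c(N3CCC3)ncnc21` reaches only a limit of the assay in this assay, namely > 50 mg/kg. The step of an at least 7.3-fold higher number from compound 1 to compound 2 (0.86 log units; beyond the scatter) is thus known only as a lower bound (the limit of > 50 mg/kg in this assay, at which 1 of the 2 values shown sits). Compound 3 `Fc1ccccc1Cn1cnc2c(N3CCCC3)ncnc21` differs from compound 2 by pyrrolidin-1-yl in place of azetidin-1-yl on an aromatic carbon. Going by the values given here, the single measured step concerns a different group, so no measured step bears directly on this change, and the direction of this assay for compound 3 stays open. Compound 3 is expected near 35 mg/kg, between 8 mg/kg and 150 mg/kg, an estimated step of an at least 1.4-fold lower number from compound 2 to compound 3 (0.15 log units; that floor lies within the scatter).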

Compound 3, dose for half-maximal effect: 12.5 mg/kg
Compound 3: middle estimate off by 2.8-fold (0.45 log units), on the high side; the measured number falls inside the stated range.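

In this assay, the five-membered ring restores a measurable dose where the four-membered ring did not (an at least 4.0-fold lower number from compound 2 to compound 3 (0.60 log units; beyond the scatter)). Compound 2 stands at a limit of the assay and not at a number, so this step is only a lower bound: the limit of > 50 mg/kg in this assay, at which 1 of the 3 values shown sits. Pyrrolidin-1-yl and the open cyclopropyl(methyl)amino group cannot be told apart at this position (a 1.8-fold higher number from compound 1 to compound 3 (0.26 log units; within the scatter)), which leaves azetidin-1-yl as the one group of the three that stands apart.

On these data alone, whether a six-membered piperidin-1-yl or morpholin-4-yl ring would hold this level stays open. So does why azetidin-1-yl stands apart.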